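Benzothiophene in place of the fluorobenzyl thioether substituent

The source may report more compounds than this note shows. Statements on the series, on what has been measured and on what is new or still open speak of the compounds shown alone.

Among the compounds with values here, compound 1 `Cc1cc(Nc2cc(-c3ccccc3)[nH]n2)n2nc(SCc3ccc(F)cc3)nc2n1` gives 3270 nM in a functional assay on MGC-803 cells (Homo sapiens) for inhibition, read by MTT assay, with a stated time of 72 h (on this read-out higher numbers stand for weaker inhibition and lower numbers for stronger inhibition), the second highest of the three numbers measured so far. Compound 3 `Cc1cc(Nc2cc(-c3ccccc3)[nH]n2)n2nc(SCc3ccc(Br)cc3)nc2n1` gives 1110 nM, and compound 2 `Cc1cc(Nc2cc(-c3ccccc3)[nH]n2)n2nc(SCC3CCCCC3)nc2n1` gives 12600 nM. On this read-out a 2.9-fold lower number from compound 1 to compound 3 (0.47 log units; beyond the scatter) and an 11-fold lower number from compound 2 to compound 3 (1.06 log units; beyond the scatter), while a 3.9-fold higher number from compound 1 to compound 2 (0.59 log units; beyond the scatter). Compound 4 `Cc1cc(Nc2cc(-c3ccccc3)[nH]n2)n2nc(SCc3csc4ccccc34)nc2n1` carries the change (1-benzothiophen-3-yl in place of 4-fluorophenyl on a saturated chain carbon bound to a sulfur). Within the data shown here, the steps that bear on it show an aromatic group on the saturated chain carbon bound to sulfur is favoured over cyclohexyl, and that the larger bromo beat fluoro. The entering 1-benzothiophen-3-yl keeps an aromatic ring and adds a second, so a modest step down is expected, a 1.8-fold lower number from compound 1 to compound 4 (0.26 log units; within the scatter). Compound 4 is therefore estimated at 1800 nM, within 700 nM to 4500 nM.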

Compound 4, half-maximal inhibitory concentration: 2280 nM
For compound 4 the middle estimate is 1.3-fold (0.10 log units) below the measured one; low and high end bracket the measured number.
By their numbers in this assay, from the lowest: compound 3; then compounds 4 and 1 (each within the scatter of the next); then compound 2.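

In this assay a second fused ring is tolerated on the saturated chain carbon bound to a sulfur: 1-benzothiophen-3-yl gives a 1.4-fold lower number from compound 1 to compound 4 (0.16 log units; within the scatter) and so does not separate from 4-fluorophenyl, while a 5.5-fold lower number from compound 2 to compound 4 (0.74 log units; beyond the scatter) extends the preference for aromatic groups over cyclohexyl to a second aromatic type. The added ring does not match 4-bromophenyl, with a 2.1-fold higher number from compound 3 to compound 4 (0.31 log units; beyond the scatter) in this comparison. No evidence at hand accounts for these steps. Going by these compounds, whether an amine, a carboxylic acid or a longer chain at this place would keep the level of the aromatic groups stays open.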